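Thiophene for methyl at the exocyclic chain carbon

A few compounds are considered here, and "the series" means these few. Any claim that something is new, unique, unknown or untested is made for them only; others in the source may bear on it.

For the measured compounds named here, compound 2 `C/C=C1\C=C(C)C2(CC2)C(C)(O)C1=O` gives 120 nM in a functional assay on SW480 cells (Homo sapiens) for antiproliferative activity (on this read-out higher numbers stand for weaker inhibition and lower numbers for stronger inhibition), the highest of the two numbers so far; compound 1 `CC1=C/C(=C\C(C)C)C(=O)C(C)(O)C12CC2` gives 30 nM, and the step of a 4.0-fold higher number from compound 1 to compound 2 (0.60 log units; beyond the scatter) is the only measured change at this place. Compound 3 `CC1=C/C(=C\c2cccs2)C(=O)C(C)(O)C12CC2` carries thiophen-2-yl in place of methyl on a double-bonded chain carbon bound to a double-bonded ring carbon. Going by the values given here, only that one step bears on it: replacing isopropyl by methyl raised the number, and compound 3 moves away from methyl again at the same place, so a lower number is expected, of about a 2.7-fold lower number from compound 2 to compound 3 (0.43 log units; beyond the scatter). The estimate for compound 3 in this assay is 45 nM, within 15 nM to 150 nM.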

Compound 3, half-maximal inhibitory concentration: > 10000 nM
Compound 3 was reported as a limit (the forecaster's own chance of this, stated with the estimate: 0%); middle value at least 220-fold (2.34 log units) away from the limit.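

At the double-bonded chain carbon, the change from alkyl to ring matters far more than the change between the two alkyl groups. In this assay compound 3 is reported only as a limit, > 10000 nM, not as a number. Thiophen-2-yl gives an at least 83-fold higher number from compound 2 to compound 3 (1.92 log units; beyond the scatter) and an at least 330-fold higher number from compound 1 to compound 3 (2.52 log units; beyond the scatter), both much larger than a 4.0-fold higher number from compound 1 to compound 2 (0.60 log units; beyond the scatter).

On these data alone, whether phenyl, furan-2-yl or a longer chain at this place would behave like thiophen-2-yl or like isopropyl stays open. How far compound 3 lies past the limit also cannot be read.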